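Swapping a Methyl for a Nitro on the Benzyl Ring

This account rests on a few compounds, and the source may have more. Where it says the series, first, only, none or still open, it means among the compounds named here.

Three compounds share one core and differ only in the aryl group that sits on the saturated chain carbon bound to an oxygen on the aromatic ring. Compound 1 `Cc1cc(C(=O)O)nn1Cc1cc(Br)ccc1OCc1ccccc1Cl` gives 28.8 nM in a functional assay on CHO-K1 cells for antagonist activity at prostaglandin E2 receptor EP1 subtype (Homo sapiens), read by FLIPR; a lower number here means a stronger inhibitor, a higher number a weaker inhibitor. Compound 2 `Cc1cc(C(=O)O)nn1Cc1cc(Br)ccc1OCc1c(F)cccc1F` gives 105 nM, and compound 3 `Cc1cccc(COc2ccc(Br)cc2Cn2nc(C(=O)O)cc2C)c1` gives 525 nM. Compound 3 therefore has the highest number of the three, with an 18-fold higher number from compound 1 to compound 3 (1.26 log units; beyond the scatter) and a 5.0-fold higher number from compound 2 to compound 3 (0.70 log units; beyond the scatter), both beyond the usual scatter, so it is the weakest inhibitor measured so far.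

Compound 4 `Cc1cc(C(=O)O)nn1Cc1cc(Br)ccc1OCc1cccc([N+](=O)[O-])c1` arises from compound 3 by a single change: nitro in place of methyl on an aromatic carbon of a six-membered aromatic ring of carbon only. Going by the values given here, none of the measured steps exchanges one substituent for another on the same aryl ring; they all replace the whole aryl group, and the large spread from a 3.6-fold higher number from compound 1 to compound 2 (0.56 log units; beyond the scatter) to an 18-fold higher number from compound 1 to compound 3 (1.26 log units; beyond the scatter) only shows that this region is sensitive. Among the compounds with values here, with no direct precedent, the expectation for compound 4 is a step of a 1.1-fold lower number from compound 3 to compound 4 (0.02 log units; within the scatter), within the scatter. Compound 4 is estimated at 500 nM, with a range from 150 nM to 1600 nM.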

Compound 4, inhibition constant: 339 nM
The estimate for compound 4 lay 1.5-fold (0.17 log units) above the measured number; measured number inside the range.
By their numbers in this assay, from the lowest: compound 1; then compound 2; then compounds 4 and 3 (each within the scatter of the next).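

Nitro in place of methyl on this aromatic carbon is the first exchange of one substituent for another on the same aryl ring, and it barely registers in this assay (a 1.5-fold lower number from compound 3 to compound 4 (0.19 log units; within the scatter)). The sensitivity seen so far therefore does not extend to this swap: 3-nitrophenyl, like 3-methylphenyl, stays clearly behind the two other aryl groups (a 3.2-fold higher number from compound 2 to compound 4 (0.51 log units; beyond the scatter); a 12-fold higher number from compound 1 to compound 4 (1.07 log units; beyond the scatter)), and among these four compounds none goes against that split. Nothing measured here accounts for this result.

Going by these compounds, whether an amine or a carboxylic acid on the same aromatic carbon would also stay within the scatter of compound 3 remains open. So does whether a longer chain, such as ethyl or propyl, in that place would leave the number equally unmoved.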